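The compounds below may be only part of what the source reports. "The series", "measured", "known", "first", "only" and "open" are said of these compounds alone.

Measured compounds in a functional assay on HeLa cells (Homo sapiens) for antiproliferative activity, read by MTT assay, with a stated time of 72 h; on this read-out higher numbers stand for weaker inhibition and lower numbers for stronger inhibition:
compound 1 `O=C(Nc1ccc(Cl)c(-c2nnc3c(Cl)cccn23)c1)c1ccc(F)cc1Cl`: > 100000 nM
compound 2 `O=C(Nc1ccc(Cl)c(-c2nnc3c(Cl)cccn23)c1)c1ccc(Cl)cc1`: > 100000 nM

The value of compound 1 in this assay is a limit of the assay, not a number. The value of compound 2 in this assay is likewise a limit. Compound 2 therefore stands at the reporting limit of this assay, with no measured activity to place it against. Within the data shown here, the single measured step, a step that the two limits leave unreadable from compound 1 to compound 2, cannot be sized because of the limit of > 100000 nM in this assay, at which 2 of the 2 values shown sit.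

Compound 3 `O=C(Nc1ccc(Cl)c(-c2nnc3c(Cl)cccn23)c1)c1cccc(Cl)c1` is not yet measured. Against compound 2 the change is 3-chlorophenyl in place of 4-chlorophenyl on a carbonyl carbon. Among the measured compounds shown here, the only measured step bears on this only in that both ends sit at the limit; it gives no readable size or direction. Compound 3 is therefore expected to give 150000 nM in this assay, with a range of 30000 nM to 1000000 nM. The step that the limit leaves unreadable from compound 2 to compound 3 is estimated to stay within the scatter, with a limit the most likely report.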

Compound 3, half-maximal inhibitory concentration: > 100000 nM
Compound 3: no number, only a limit; the forecaster's own chance of this, stated with the estimate: 80%; the middle value lies beyond the limit too.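

No step can be read among compound 1, compound 2 and compound 3 in this assay, because all three values are limits and not numbers: the limit of > 100000 nM in this assay, at which 3 of the 3 values shown sit.

The compounds shown leave open whether any group on the carbonyl carbon gives a measurable value on the shared core.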